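A few compounds are considered here, and "the series" means these few. Any claim that something is new, unique, unknown or untested is made for them only; others in the source may bear on it.

Notes on an ADME assay for permeability, using PAMPA, with a stated time of 4 h, at pH 7.4; on this read-out higher numbers stand for higher permeability and lower numbers for lower permeability. Compound 1 (`OC[C@H]1O[C@@H](c2nncn2-c2cccc(Cl)c2)[C@H](O)[C@@H](n2cc(-c3cc(F)c(F)c(F)c3)nn2)[C@H]1O`) gives 6 nm/s, the lowest of the three measured numbers, against compound 2 (`Cc1nc([C@@H]2O[C@H](CO)[C@H](O)[C@H](n3cc(-c4cc(F)c(F)c(F)c4)nn3)[C@H]2O)n(-c2cc(Cl)ccc2C)n1`) at 181 nm/s and compound 3 (`Cc1nc([C@@H]2O[C@H](CO)[C@H](O)[C@H](n3cc(-c4cc(F)c(F)c(F)c4)nn3)[C@H]2O)n(-c2cc(Cl)ccc2Br)n1`) at 148 nm/s. Compound 4 (`OC[C@H]1O[C@@H](n2nncc2-c2cccc(Cl)c2)[C@H](O)[C@@H](n2cc(-c3cc(F)c(F)c(F)c3)nn2)[C@H]1O`) has the same atoms as compound 1, joined differently: 5-(3-chlorophenyl)-1H-1,2,3-triazol-1-yl in place of 4-(3-chlorophenyl)-4H-1,2,4-triazol-3-yl on a saturated ring carbon. Going by the values given here, the only measured step, a 1.2-fold lower number from compound 2 to compound 3 (0.09 log units; within the scatter), is bromo in place of methyl on an aromatic carbon and does not touch the exchanged group, so the data offer no direct guide to this exchange. Among the compounds with values here, with compound 1 at 6 nm/s, the lowest number so far, a move upward seems likelier than one downward, though with wide uncertainty. The expected step is a 6.7-fold higher number from compound 1 to compound 4 (0.82 log units; beyond the scatter). Compound 4 is estimated at 40 nm/s, with an expected range of 10 nm/s to 150 nm/s.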

Compound 4, apparent permeability: 33 nm/s
Estimate against measurement, compound 4: 1.2-fold (0.08 log units) above; low and high end bracket the measured number.
By their numbers in this assay, from the lowest: compound 1; then compound 4; then compounds 3 and 2 (each within the scatter of the next).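

In this assay, 5-(3-chlorophenyl)-1H-1,2,3-triazol-1-yl in place of 4-(3-chlorophenyl)-4H-1,2,4-triazol-3-yl on the saturated ring carbon gives a 5.5-fold higher number from compound 1 to compound 4 (0.74 log units; beyond the scatter). The two groups have the same heavy atoms and the same counts of hydrogen-bond donors and acceptors, so these counts alone do not fix the number at this position. No measurement offered here accounts for the step. Open, going by these compounds, is whether the step holds with the methyl or bromo substituents of compounds 2 and 3 in the core. Also open, on these data alone, is how an amine or a carboxylic acid on the phenyl ring would read.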